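The source may hold more compounds than are shown below. What is called first, only, known or untested is meant among the compounds shown, and "the series" means these compounds.

Working notes on the series. In a functional assay on K562 cells (Homo sapiens) for inhibition, read by trypan blue exclusion, with a stated time of 72 h (on this read-out lower numbers stand for stronger inhibition and higher numbers for weaker inhibition), compound 1 (`Cn1c(=O)c(S(=O)(=O)c2ccc(F)cc2)cc2cnc(Nc3ccc4occc4c3)nc21`) stands at 5000 nM and compound 2 (`Cn1c(=O)c(S(=O)(=O)c2ccc(F)cc2F)cc2cnc(Nc3ccc4occc4c3)nc21`) at 15000 nM while compound 3 (`COc1ccc(Nc2ncc3cc(S(=O)(=O)c4ccc(Cl)cc4)c(=O)n(C)c3n2)cc1`) sits at 15000 nM on the same read-out. Compound 2 and compound 3 are therefore level, and together they hold the highest number of the three, so compound 2 starts from the weak end of what has been measured.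

Compound 4 (`Cn1c(=O)c(S(=O)(=O)c2ccc(F)cc2F)cc2cnc(Nc3cnc4[nH]ccc4c3)nc21`) changes one group of compound 2 (a group of 9 heavy atoms (7 carbon, 2 nitrogen; one five-membered aromatic ring with 1 hetero atom, one six-membered aromatic ring with 1 hetero atom) in place of a group of 9 heavy atoms (8 carbon, 1 oxygen; one five-membered aromatic ring with 1 hetero atom, one six-membered aromatic ring of carbon only), on a nitrogen on an aromatic ring); the 1-benzofuran-5-yl leaves, on a nitrogen on an aromatic ring. Among the measured compounds shown here, no measured step covers this swap. For the measured compounds named here, the one single-place step available (a 3.0-fold higher number from compound 1 to compound 2 (0.48 log units; beyond the scatter)) is modest and beyond the scatter, but it is fluoro in place of hydrogen on an aromatic carbon, a different change in a different place, so it bears only loosely. Compound 3 also carries another group on that nitrogen, but it differs from compound 2 elsewhere too, so the two values cannot isolate that group.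

With no direction supported, no step beyond the scatter is expected in this assay and the range is kept wide. The estimated change (a 1.5-fold lower number from compound 2 to compound 4 (0.18 log units; within the scatter)) is correspondingly small. For compound 4 the estimated value is 10000 nM with an expected range of 2000 nM to 40000 nM as the working figure.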

Compound 4, half-maximal inhibitory concentration: 750 nM
Compound 4: the middle estimate sits 13-fold (1.12 log units) above what was measured; the whole stated range lies above it.
By their numbers in this assay, from the lowest: compound 4; then compound 1; then compounds 2 and 3 (each within the scatter of the next).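

In this assay, the group on the nitrogen on an aromatic ring proves to be a sensitive place in the series: replacing the 1-benzofuran-5-yl with the group of 7 carbon and 2 nitrogen atoms gives a 20-fold lower number from compound 2 to compound 4 (1.30 log units; beyond the scatter). Among the compounds shown here, the only earlier step, a 3.0-fold higher number from compound 1 to compound 2 (0.48 log units; beyond the scatter), was modest and lay at another place, so this is the first sign that a change on this nitrogen can move the number by a large amount, even with 9 heavy atoms on both sides of the swap and the rest of compound 2 untouched. The entering group has 1 hydrogen-bond donor where the leaving group has 0 and a ring nitrogen in its six-membered ring, but nothing at hand bears on why the number fell.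

For the compounds shown here, the single step changes the ring nitrogen and the five-membered ring's hetero atom together, so it cannot tell which of the two matters. Also open, as far as these compounds go, are whether the same swap gives a step of similar size on the core of compound 1, with its single fluoro, and how an aminoalkyl chain or a carboxylic acid on the entering group would fare.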